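The source may hold more compounds than are shown below. What is called first, only, known or untested is meant among the compounds shown, and "the series" means these compounds.

Measured in a functional assay on K562 cells (Homo sapiens), read by MTT assay, with a stated time of 72 h; a higher number here means a weaker inhibitor, a lower number a stronger inhibitor:
- Compound 1 `CNc1ncnc2c1c(-c1cc3ccccc3o1)cn2[C@@H]1O[C@H](CO)[C@@H](O)[C@H]1O` gives > 20000 nM as a limit.
- Compound 2 `Cc1ncnc2c1c(-c1ccsc1)cn2[C@@H]1O[C@H](CO)[C@@H](O)[C@H]1O` gives 5550 nM as a number.
- Compound 3 `Cc1ncnc2c1c(-c1cc3ccccc3o1)cn2[C@@H]1O[C@H](CO)[C@@H](O)[C@H]1O` gives > 20000 nM as a limit.

Compound 3 stands only at a limit, the same one as compound 1, so its true position is unread. Compound 4 `Cc1ncnc2c1c(I)cn2[C@@H]1O[C@H](CO)[C@@H](O)[C@H]1O` carries iodo in place of 1-benzofuran-2-yl on an aromatic carbon, counted as iodo in place of 1-benzofuran-2-yl on an aromatic carbon in full. Among the compounds with values here, the one step at this place is an at least 3.6-fold higher number from compound 2 to compound 3 (0.55 log units; beyond the scatter) and, read backwards, it points to a lower number once 1-benzofuran-2-yl leaves. The step that the two limits leave unreadable from compound 1 to compound 3 concerns another group and gives no size. Within the data shown here, no iodo compound has been measured, so the size remains uncertain. In this assay the expected change is an at least 5.0-fold lower number from compound 3 to compound 4 (0.69 log units; beyond the scatter) as a drop of at least modest size. Compound 4 is estimated at 4000 nM with an expected range of 600 nM to 20000 nM for now.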

Compound 4, half-maximal inhibitory concentration: > 20000 nM
Compound 4: only a limit was reported; the forecaster's own chance of this, stated with the estimate: 25%; middle value at least 5.0-fold (0.69 log units) away from the limit.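

In this assay, compound 4 gives > 20000 nM, which is a limit. Iodo in place of thiophen-3-yl gives an at least 3.6-fold higher number from compound 2 to compound 4 (0.55 log units; beyond the scatter), so at this position both a single iodine atom and the larger fused 1-benzofuran-2-yl end up weaker than thiophen-3-yl. The step between compound 3 and compound 4 cannot be read because both stand at the same limit: the limit of > 20000 nM in this assay, at which 3 of the 4 values shown sit.

As far as these compounds go, compound 2 gives 5550 nM, and it remains open whether any other group here can go lower. A furan-3-yl ring or a small amine at this place would test how specific thiophen-3-yl is.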